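From a sulfamoyl to an ethylsulfanyl side chain

The source may hold more compounds than are shown below. What is called first, only, known or untested is meant among the compounds shown, and "the series" means these compounds.

Measured in a functional assay on the whole organism with Rattus norvegicus as the target; on this read-out higher numbers stand for an effect only at larger amounts of compound and lower numbers for an effect already at smaller amounts:
- Compound 1 `C#CCn1c(=N)sc2cc(OC(F)(F)F)ccc21`: 4 mg/kg
- Compound 2 `COC(=O)Cn1c(=N)sc2cc(OC(F)(F)F)ccc21`: > 10 mg/kg, a limit of the assay
- Compound 3 `N=c1sc2cc(OC(F)(F)F)ccc2n1CCS(N)(=O)=O`: 6 mg/kg

In this assay, compound 3 at 6 mg/kg and compound 1 at 4 mg/kg lie within the scatter of each other, as a 1.5-fold higher number from compound 1 to compound 3 (0.18 log units; within the scatter) shows. Going by the values given here, these are the only two exact numbers so far. Compound 2 gives only a limit, > 10 mg/kg.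

The next compound, compound 4 `CCSCCn1c(=N)sc2cc(OC(F)(F)F)ccc21`, has ethylsulfanyl in place of sulfamoyl on a saturated chain carbon, two bonds along the chain from an aromatic nitrogen. Among the compounds with values here, no measured step makes this exact exchange, so the guidance is indirect. The side-chain change in a 1.5-fold higher number from compound 1 to compound 3 (0.18 log units; within the scatter) stayed within the scatter. In contrast, an at least 2.5-fold higher number from compound 1 to compound 2 (0.39 log units; beyond the scatter) went beyond it, though only as a bound, and the floor of an at least 1.6-fold lower number from compound 2 to compound 3 (0.22 log units; that floor lies within the scatter) lies within the scatter. On these steps, no shift beyond the scatter is expected, although a modest rise in the number remains possible.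

The expected step is a 1.2-fold lower number from compound 3 to compound 4 (0.08 log units; within the scatter).

The estimate for compound 4 is 5 mg/kg, with an expected range from 2 mg/kg to 12 mg/kg.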

Compound 4, dose for half-maximal effect: 2.2 mg/kg
For compound 4 the middle estimate is 2.3-fold (0.36 log units) above the measured one; the range from low to high includes it.
By their numbers in this assay, from the lowest: compounds 4, 1 and 3 (each within the scatter of the next, the first and the last beyond it). At a limit, above all of these: compound 2.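

In this assay, going by these compounds alone, ethylsulfanyl in place of sulfamoyl on a saturated chain carbon, two bonds along the chain from an aromatic nitrogen, gives a 2.7-fold lower number from compound 3 to compound 4 (0.44 log units; beyond the scatter) and is the first step here beyond the scatter with an exact number at both ends, showing that this side chain can move the number down as well as up. Set against the ethynyl side chain, the change gives a 1.8-fold lower number from compound 1 to compound 4 (0.26 log units; within the scatter) and so does not separate the two, which leaves the earlier finding that the position tolerates quite different groups standing beside the new one. The comparison with the methoxycarbonyl side chain reads an at least 4.5-fold lower number from compound 2 to compound 4 (0.65 log units; beyond the scatter), and this is a bound and not an exact size: the limit of > 10 mg/kg in this assay, at which 1 of the 4 values shown sits.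

Whether the sulfur of the ethylsulfanyl group matters stays open, since the compounds shown include no matching ether, sulfoxide or sulfone and no plain alkyl chain of the same reach. As far as these compounds go, they also hold no amine or carboxylic acid at the chain end and no longer chain, and the rest of the core stays the same throughout, so the reach of this result beyond it is unknown.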